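Replacing the Dichlorophenyl Group of Compound 3 with Hydroxynaphthyl

A few compounds are considered here, and "the series" means these few. Any claim that something is new, unique, unknown or untested is made for them only; others in the source may bear on it.

Three compounds sharing one core have been examined in a functional assay on Ehrlich cells (Mus musculus) for cytotoxicity, read by trypan blue exclusion, with a stated time of 2 h, tested at 100 ug/mL; a higher number here means a stronger effect of the compound at the concentration tested, a lower number a weaker effect. Compound 1 `N#CC1=C(N)N(c2ccc(S(N)(=O)=O)cc2)C2=C(CCCC2)C1c1cccc([N+](=O)[O-])c1` gives 12%; compound 2 `N#CC1=C(N)N(c2ccc(S(N)(=O)=O)cc2)C2=C(CCCC2)C1c1ccccc1Cl` gives 10%; compound 3 `N#CC1=C(N)N(c2ccc(S(N)(=O)=O)cc2)C2=C(CCCC2)C1c1ccc(Cl)c(Cl)c1` gives 50%. Compound 3 stands highest of the three numbers: the step of a number 38 percentage points higher from compound 1 to compound 3 (beyond the scatter) and the step of a number 40 percentage points higher from compound 2 to compound 3 (beyond the scatter) are both large and beyond the scatter, while the step of a number 2 percentage points lower from compound 1 to compound 2 (within the scatter) lies within it. The group on the saturated ring carbon therefore shifts the read-out strongly.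

Compound 4 `N#CC1=C(N)N(c2ccc(S(N)(=O)=O)cc2)C2=C(CCCC2)C1c1c(O)ccc2ccccc12` is not yet measured. The change from compound 3 to compound 4 is 2-hydroxynaphthalen-1-yl in place of 3,4-dichlorophenyl on a saturated ring carbon. Going by the values given here, no measured step carries this change, so its direction cannot be read from the numbers; the two large steps toward compound 3 show only that changing this group can move the read-out widely. Among the compounds with values here, compound 3 is the only compound above the low-lying pair, so a fall back toward compound 1 and compound 2 is as plausible as a further rise. For compound 4 the expected result is 25%, spanning 5% to 55%, which amounts to an estimated step of a number 25 percentage points lower from compound 3 to compound 4 (beyond the scatter).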

Compound 4, a percentage reported as activity, at one concentration (the size of the read-out at that concentration, not a potency): 50%
For compound 4 the middle estimate is 25 percentage points below the measured one; the measured number falls inside the stated range.
By their numbers in this assay, from the lowest: compounds 2 and 1 (each within the scatter of the next); then compounds 3 and 4 (each within the scatter of the next).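

In this assay, going by these compounds alone, this position on the saturated ring carbon accepts a far larger exchange than the earlier compounds covered, with no change at the digits printed from compound 3 to compound 4 (within the scatter) even though 2-hydroxynaphthalen-1-yl has 2 six-membered aromatic rings of carbon only, 1 hydrogen-bond donor and 1 hydrogen-bond acceptor, and 3,4-dichlorophenyl has one such ring, 0 donors and 0 acceptors. The high read-out is therefore not confined to a chlorine-bearing phenyl group: the new group also gives a number 40 percentage points higher from compound 2 to compound 4 (beyond the scatter) and a number 38 percentage points higher from compound 1 to compound 4 (beyond the scatter). No evidence at hand says why these two different groups give read-outs within the scatter of each other.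

The compounds shown do not separate the contribution of the hydroxyl from that of the second ring, which a plain naphthalen-1-yl or a 2-hydroxyphenyl group could address. They also leave open how an aryl group carrying an amine or a carboxylic acid would read here.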